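Para-methyl analogue of the dimethyl ester: expected read-out

The source may report more compounds than this note shows. Statements on the series, on what has been measured and on what is new or still open speak of the compounds shown alone.

Going by the values given here, the series so far holds three measured compounds. Compound 1 `COP(=O)(OC)[Se]c1ccccc1` gives 10.4% in a functional assay, tested at 50 uM; on this read-out lower numbers stand for a weaker effect and higher numbers for a stronger effect at the one concentration tested. Compound 2 `CCCCOP(=O)(OCCCC)[Se]c1ccccc1` gives 8.76% in this assay, and compound 3 `O=P(OCc1ccccc1)(OCc1ccccc1)[Se]c1ccccc1` gives 3.06% in the same read-out. Compound 1 heads the three numbers as written, but neither compound 2 nor compound 3 is separated from it by more than the usual scatter of repeated measurements, so the three are best read as one low level of effect rather than as a ranking. Among the compounds with values here, no pair among them differs in a single place, so no step between measured compounds can be drawn on.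

The next compound, compound 4 `COP(=O)(OC)[Se]c1ccc(C)cc1`, is the point of interest. Relative to compound 1 the change is methyl in place of hydrogen on an aromatic carbon. Within the data shown here, with no measured step to set a scale, and with all three numbers so far sitting close together near the bottom of the read-out, the expectation is a step from compound 1 to compound 4 of a number 0.4 percentage points lower from compound 1 to compound 4 (within the scatter), which is not expected to reach beyond the scatter in either direction. Compound 4 is therefore estimated at 10% in this assay, with a plausible range from 3% to 20%.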

Compound 4, a percentage reported as activity, at one concentration (the size of the read-out at that concentration, not a potency): 12.5%
Compound 4: middle estimate off by 2.5 percentage points, on the low side; measured number inside the range.
By their numbers in this assay, from the lowest: compounds 3, 2, 1 and 4 (each within the scatter of the next).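

Going by these compounds alone, the step of a number 2.1 percentage points higher from compound 1 to compound 4 (within the scatter) in this assay is the first comparison between compounds that differ in one place, and it gives the first scale for any change on the aromatic ring. At this position, para to a group of 7 heavy atoms, methyl in place of hydrogen leaves compound 4 inseparable from compound 1, so this one added carbon does not lift the read-out out of the low level shared by the series. No measurement bearing on this step is available to explain it.

Still open, on these data alone, is whether a different group at the same position, such as an amine, a carboxylic acid or a longer chain, would give a step beyond the scatter, and whether the methyl would give a similar step on the butyl esters of compound 2 or the benzyl esters of compound 3. Also open, as far as these compounds go, is how these compounds compare at other concentrations: the read-out describes only the size of the effect at the one concentration tested.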